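The compounds below may be only part of what the source reports. "The series", "measured", "known", "first", "only" and "open" are said of these compounds alone.

Compound 3 `CC(=O)OCC(CCn1cc(C#CC2CC2)c(=O)n(C(=O)c2ccccc2)c1=O)COC(C)=O` is known in a functional assay on HeLa cells (Homo sapiens) for antiproliferative activity, read by MTT assay, with a stated time of 72 h (on this read-out lower numbers stand for stronger inhibition and higher numbers for weaker inhibition), only as a limit, where compound 3 gives > 100000 nM. Compound 1 `O=c1[nH]c(=O)n(CCC(CO)CO)cc1-c1ccco1` likewise gives > 100000 nM, itself a limit. Compound 2 `CC(=O)OCC(CCn1cc(C#CCc2ccccc2)c(=O)n(C(=O)c2ccccc2)c1=O)COC(C)=O` gives 29900 nM. Among the measured compounds shown here, the one measured step, an at least 3.3-fold higher number from compound 2 to compound 3 (0.52 log units; beyond the scatter), runs into the limit of > 100000 nM in this assay, at which 2 of the 3 values shown sit, and so marks only the smallest size that step can have. Compound 4 `CC(=O)OCC(CCn1cc(C#CCCCCl)c(=O)n(C(=O)c2ccccc2)c1=O)COC(C)=O` differs from compound 3 by 3-chloropropyl in place of cyclopropyl on a triple-bonded carbon. For the measured compounds named here, no measured step covers the exchange of a small ring for an open chlorinated chain. Given that the single step, an at least 3.3-fold higher number from compound 2 to compound 3 (0.52 log units; beyond the scatter), ended at the limit, compound 4 is expected to remain near it, a step of a number no higher from compound 3 to compound 4 (the limit leaves the size open). Compound 4 is thus estimated at 100000 nM, between 30000 nM and 300000 nM.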

Compound 4, half-maximal inhibitory concentration: 52800 nM
Compound 4: the middle estimate sits 1.9-fold (0.28 log units) above what was measured; the measured number falls inside the stated range.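

In this assay, 3-chloropropyl on the triple-bonded carbon gives a measured number where cyclopropyl gave none, with an at least 1.8-fold lower number from compound 3 to compound 4 (0.27 log units; that floor lies within the scatter). Compound 3 stands only at a limit, so this step is a floor: the limit of > 100000 nM in this assay, at which 2 of the 4 values shown sit. The 3-chloropropyl and benzyl groups on that carbon are not separated, with a 1.8-fold higher number from compound 2 to compound 4 (0.25 log units; within the scatter).

From the compounds shown here alone, it remains open whether the chlorine itself counts, a question that a plain propyl chain or an amine in its place could answer. Going by these compounds, it also remains open whether a longer chain would lower the number further.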